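Swapping the fused heteroaryl amide in a sulfone-bearing series

The source may hold more compounds than are shown below. What is called first, only, known or untested is meant among the compounds shown, and "the series" means these compounds.

Two compounds share a common right-hand half, a benzylamide carrying a phenyl sulfone, and differ only in the fused bicyclic heteroaryl ring attached to the carbonyl carbon. Compound 1 `O=C(NCc1ccc(S(=O)(=O)c2ccccc2)cc1)c1nc2cnccc2[nH]1` gives 7100 nM in an assay for inhibition of Nicotinamide phosphoribosyltransferase (Homo sapiens), read by mass spectrometry, with stated times of 15 min and 30 min; on this read-out lower numbers stand for stronger inhibition and higher numbers for weaker inhibition. Compound 2 `O=C(NCc1ccc(S(=O)(=O)c2ccccc2)cc1)c1cn2ccnc2cn1` gives 150 nM in this assay, which is the lowest of the two numbers and places it well apart from compound 1, the step being a 47-fold lower number from compound 1 to compound 2 (1.68 log units; beyond the scatter).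

Compound 3 `O=C(NCc1ccc(S(=O)(=O)c2ccccc2)cc1)c1ccc2nncn2c1` is built from the same atoms as compound 2, but arranged differently: a group of 9 heavy atoms (6 carbon, 3 nitrogen; one five-membered aromatic ring with 3 hetero atoms, one six-membered aromatic ring with 1 hetero atom) in place of a group of 9 heavy atoms (6 carbon, 3 nitrogen; one five-membered aromatic ring with 2 hetero atoms, one six-membered aromatic ring with 2 hetero atoms), on a carbonyl carbon. Within the data shown here, the only measured step that bears on this kind of change is a 47-fold lower number from compound 1 to compound 2 (1.68 log units; beyond the scatter), and it shows that rearranging the heteroatoms of this bicyclic ring can move the number a long way in either direction. Since compound 2 holds the lowest number seen so far, the more likely outcome of a further rearrangement is a higher number, though the scale is uncertain. Compound 3 is therefore expected to give 700 nM in this assay, within a range of 120 nM to 4500 nM, an expected step of a 4.7-fold higher number from compound 2 to compound 3 (0.67 log units; beyond the scatter).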

Compound 3, half-maximal inhibitory concentration: 370 nM
The estimate for compound 3 lay 1.9-fold (0.28 log units) above the measured number; the measured number falls inside the stated range.
By their numbers in this assay, from the lowest: compound 2; then compound 3; then compound 1.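

Compound 3 shows that compound 2 is not the only arrangement of these ring atoms to give a low number: moving to a five-membered ring with 3 hetero atoms and a six-membered ring with 1 hetero atom gives only a 2.5-fold higher number from compound 2 to compound 3 (0.39 log units; beyond the scatter) in this assay, a modest step though beyond the scatter. Set against the ring of compound 1, the same ring gives a 19-fold lower number from compound 1 to compound 3 (1.28 log units; beyond the scatter), a large step, so two of the three rings on this carbonyl carbon sit well apart from the third. The group that leaves and the group that enters have the same hydrogen-bond donor and acceptor counts and no net charge, so those counts do not separate compound 2 from compound 3, and no measurement at hand accounts for the gap between them.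

Going by these compounds, all three compounds carry the same benzylamide with its phenyl sulfone, so it remains open whether this order of rings would hold with a different group in place of that sulfone. On these data alone, it is also open how either of the two better rings would respond to a small added group such as a methyl or an amine.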